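The compounds below may be only part of what the source reports. "The series", "measured", "known", "first", "only" and "open" are said of these compounds alone.

Working notes on the series.

Among the compounds with values here, compound 3 `O/N=C(\CCN1CCN(c2ccccn2)CC1)c1ccc(F)cc1` gives 74% in a functional assay on HEK293 cells with D(4) dopamine receptor (Homo sapiens) as the target, read by FLIPR (a lower number here means a smaller maximal response, a higher number a larger maximal response), the highest of the three numbers in hand, yet no step to it clears the scatter: from compound 2 `O/N=C(\CCN1CCN(c2ccccn2)CC1)c1cccc(Cl)c1`, which gives 73%, the step is a number 1 percentage points higher from compound 2 to compound 3 (within the scatter), and from compound 1 `O/N=C(\CCN1CCN(c2ccccn2)CC1)c1ccccc1`, which gives 70%, it is a number 4 percentage points higher from compound 1 to compound 3 (within the scatter). The remaining step, a number 3 percentage points higher from compound 1 to compound 2 (within the scatter), is also within the scatter.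

Compound 4 `Cc1cc(C)cc(/C(CCN2CCN(c3ccccn3)CC2)=N/O)c1` is not yet measured. Its change from compound 3 is 3,5-dimethylphenyl in place of 4-fluorophenyl on a carbon with a double bond to nitrogen.

All three measured steps concern the same aromatic ring on the carbon with a double bond to nitrogen, and each changed the largest response by no more than the scatter. The change to compound 4 stays on that ring, so no step beyond the scatter is expected in this assay, in either direction. Compound 4 is therefore estimated at 72%, between 60% and 84%, an expected step of a number 2 percentage points lower from compound 3 to compound 4 (within the scatter).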

Compound 4, largest response reached (reported as efficacy), in percent of the reference or control that the assay uses: 55%
Compound 4: the middle estimate sits 17 percentage points above what was measured; measured number below the stated range.
By their numbers in this assay, from the lowest: compound 4; then compounds 1, 2 and 3 (each within the scatter of the next).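

Within the data shown here, the aromatic ring on the carbon with a double bond to nitrogen is less indifferent in this assay than the earlier compounds suggested: the steps of a number 19 percentage points lower from compound 3 to compound 4 (beyond the scatter) and a number 18 percentage points lower from compound 2 to compound 4 (beyond the scatter) and a number 15 percentage points lower from compound 1 to compound 4 (beyond the scatter) are the first to lie beyond the scatter. All three point the same way, so among the four rings shown, only 3,5-dimethylphenyl separates from the others, while phenyl, 3-chlorophenyl and 4-fluorophenyl remain within the scatter of one another. The data at hand offer no explanation for the lower maximal response.

Still open, going by these compounds, is whether the fall follows the methyl groups themselves or any pair of groups on this ring. A ring with a single methyl and 3,5-dichlorophenyl would separate these two readings.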